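A few compounds are considered here, and "the series" means these few. Any claim that something is new, unique, unknown or untested is made for them only; others in the source may bear on it.

Measured in a functional assay on HeLa cells (Homo sapiens) for cytotoxicity, read by MTT assay, with a stated time of 72 h; a lower number here means a stronger inhibitor, a higher number a weaker inhibitor:
- compound 1 `O=C(COc1ccccc1)Nc1nnc(-c2ccc(O)c(O)c2)s1`: 51300 nM
- compound 2 `O=C(Nc1nnc(-c2cccc(O)c2O)s1)c1ccccc1`: 21800 nM
- compound 3 `O=C(Nc1nnc(-c2ccc(O)c(O)c2)s1)C1CCCCC1`: 34500 nM

Compound 2, at 21800 nM, lies within the scatter of compound 3, at 34500 nM. Compound 1 has a higher number than compound 2, and that gap goes beyond the scatter.

Next is compound 4 `O=C(Nc1nnc(-c2cccc(O)c2O)s1)C1CCCCC1`, which carries cyclohexyl in place of phenyl on a carbonyl carbon of compound 2 (cyclohexyl in place of phenyl on a carbonyl carbon). Among the measured compounds shown here, no measured pair shows this exact replacement. The nearest evidence is a 1.5-fold lower number from compound 1 to compound 3 (0.17 log units; within the scatter), where cyclohexyl replaces phenoxymethyl on a carbonyl carbon. That step stays within the scatter, but it starts from a different group and sits on the core of compound 1, not the core of compound 2, so it is only indirect support. No step beyond the scatter is therefore expected in this assay.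

The expected value for compound 4 is 25000 nM, with an estimated range of 11000 nM to 55000 nM. This estimate corresponds to an expected 1.1-fold higher number from compound 2 to compound 4 (0.06 log units; within the scatter).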

Compound 4, half-maximal inhibitory concentration: 91600 nM
Beside the measured number, compound 4's estimate is 3.7-fold (0.56 log units) below it; the measured number lies above the stated range.
By their numbers in this assay, from the lowest: compounds 2, 3, 1 and 4 (each within the scatter of the next, the first and the last beyond it).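

On the core of compound 2, the group on the carbonyl carbon matters in this assay: with cyclohexyl in place of phenyl there is a 4.2-fold higher number from compound 2 to compound 4 (0.62 log units; beyond the scatter) as the result. Phenyl and cyclohexyl have the same count of heavy atoms and neither has a hydrogen-bond donor or acceptor, so the printed difference between them is an aromatic against a non-aromatic ring, whereas a 1.5-fold lower number from compound 1 to compound 3 (0.17 log units; within the scatter) on the other core gave no step beyond the scatter, from a different leaving group. No measurement at hand bears on the cause of this step.

On these data alone, how phenyl and cyclohexyl compare on the core of compound 1 remains open, so it is unknown whether this step holds beyond the core of compound 2. Also open, as far as these compounds go, is whether a piperidine ring or an open hexyl chain on the carbonyl carbon would track compound 2 or compound 4.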